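The compounds below may be only part of what the source reports. "The series", "measured", "known", "first", "only" and "open" are said of these compounds alone.

Working notes on the series.

The shared core carries a phenoxyphenoxy-acetone unit whose chain carbon bound to the carbonyl is linked to a nitrogen heterocycle. Compound 1 `O=C(COc1ccc(Oc2ccccc2)cc1)Cn1ncnn1` carries a 2H-tetrazol-2-yl there and in an assay on microsomes from brain for inhibition of Fatty-acid amide hydrolase 1 (Rattus norvegicus), read by fluorescence and HPLC, with a stated time of 45 min (a higher number here means a weaker inhibitor, a lower number a stronger inhibitor), compound 1 gives 8 nM. Compound 2 `O=C(COc1ccc(Oc2ccccc2)cc1)Cn1ncc2ccccc21` carries a 1H-indazol-1-yl in its place and in this assay compound 2 gives 2600 nM, the step of a 330-fold higher number from compound 1 to compound 2 (2.51 log units; beyond the scatter). Compound 3 `COC(=O)Nc1ccc2c(cnn2CC(=O)COc2ccc(Oc3ccccc3)cc2)c1` adds a (methoxycarbonyl)amino on an aromatic carbon of the indazole and in this assay compound 3 gives 4000 nM; the step of a 1.5-fold higher number from compound 2 to compound 3 (0.19 log units; within the scatter). Compound 3 thus stands at the highest of the three numbers, though its gap to compound 2 is within the scatter.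

Compound 4 `O=C(COc1ccc(Oc2ccccc2)cc1)Cn1ncc2cc(C(=O)NS(=O)(=O)c3ccccc3)ccc21` is not yet measured. It differs from compound 3 by (phenylsulfonyl)carbamoyl in place of (methoxycarbonyl)amino on an aromatic carbon. The step that bears on this is the one onto the same aromatic carbon, a 1.5-fold higher number from compound 2 to compound 3 (0.19 log units; within the scatter), which was within the scatter; the large step of a 330-fold higher number from compound 1 to compound 2 (2.51 log units; beyond the scatter) concerns the heterocycle itself and does not speak to a substituent change. On this basis the step of no change at the digits printed from compound 3 to compound 4 (within the scatter) is expected to stay within the scatter, with no clear direction. Compound 4 is therefore estimated at 4000 nM in this assay, in the range 1300 nM to 12000 nM.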

Compound 4, half-maximal inhibitory concentration: 4700 nM
The estimate for compound 4 lay 1.2-fold (0.07 log units) below the measured number; the measured number falls inside the stated range.
By their numbers in this assay, from the lowest: compound 1; then compounds 2, 3 and 4 (each within the scatter of the next).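

In this assay the step of a 1.2-fold higher number from compound 3 to compound 4 (0.07 log units; within the scatter) and the step of a 1.8-fold higher number from compound 2 to compound 4 (0.26 log units; within the scatter) both lie within the scatter. On this aromatic carbon of the six-membered aromatic ring of carbon only, a (phenylsulfonyl)carbamoyl with 12 heavy atoms and its own aromatic ring therefore cannot be told apart from either a (methoxycarbonyl)amino with 5 heavy atoms or hydrogen, a reading that had previously rested on a single substituent. Among these compounds, the step of a 330-fold higher number from compound 1 to compound 2 (2.51 log units; beyond the scatter) thus remains the only step beyond the scatter, and nothing on hand explains why these changes at the aromatic carbon leave the number where it is.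

Open, going by these compounds, is whether a smaller group at this same aromatic carbon, such as an amine or a carboxylic acid, would also stay within the scatter of compound 2, and whether the same holds for the other aromatic carbons of that ring. Also open, on these data alone, is whether another nitrogen heterocycle in place of the 1H-indazol-1-yl, such as a 1,2,3-triazole, would lie closer to compound 1 with its 8 nM in this assay than to compound 2.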